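Working notes: from compound 3 to compound 4

The source may report more compounds than this note shows. Statements on the series, on what has been measured and on what is new or still open speak of the compounds shown alone.

In an in vitro assay on Sf21 cells for inhibition of high affinity 3',5'-cyclic-AMP phosphodiesterase 7A (Homo sapiens), read by scintillation proximity assay, with a stated time of 30 min (a lower number here means a stronger inhibitor, a higher number a weaker inhibitor), compound 1 `CCN(CC)c1ccc(NC(=O)c2cn(Cc3c(F)cccc3F)c3ccc(=O)[nH]c3c2=O)cc1` gives 46 nM, compound 2 `O=C(O)Cc1ccc(NC(=O)c2cn(Cc3c(F)cccc3F)c3ccc(=O)[nH]c3c2=O)cc1` gives 176 nM, and compound 3 `COc1cc(NC(=O)c2cn(Cc3ccccc3F)c3ccc(=O)[nH]c3c2=O)cc(OC)c1OC` gives 206 nM, the highest of the three numbers; compound 3 and compound 2 lie within the scatter of each other, while the gap from compound 3 to compound 1 is beyond it. Going by the values given here, the only one-place step measured, a 3.8-fold higher number from compound 1 to compound 2 (0.58 log units; beyond the scatter), sits at the other end of the shared core and not on the saturated chain carbon bound to an aromatic nitrogen. Compound 4 `COc1cc(NC(=O)c2cn(Cc3ccc(F)cc3Cl)c3ccc(=O)[nH]c3c2=O)cc(OC)c1OC` differs from compound 3 by 2-chloro-4-fluorophenyl in place of 2-fluorophenyl on a saturated chain carbon bound to an aromatic nitrogen. Among the compounds with values here, no measured step bears on this change, so in this assay no shift beyond the scatter is expected, a 1.0-fold lower number from compound 3 to compound 4 (0.01 log units; within the scatter). Compound 4 is estimated at 200 nM, with a range of 70 nM to 600 nM.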

Compound 4, half-maximal inhibitory concentration: 192 nM
Estimate against measurement, compound 4: 1.0-fold (0.02 log units) above; low and high end bracket the measured number.
By their numbers in this assay, from the lowest: compound 1; then compounds 2, 4 and 3 (each within the scatter of the next).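

On a saturated chain carbon bound to an aromatic nitrogen, 2-chloro-4-fluorophenyl in place of 2-fluorophenyl leaves the number in this assay within the scatter, with a 1.1-fold lower number from compound 3 to compound 4 (0.03 log units; within the scatter). Going by these compounds alone, this is the first measured step at this position, and the ring here carries a chlorine without a shift beyond the scatter in this pair. Nothing available explains this result. Open, from the compounds shown here alone, is whether a nitrile on this ring, or a longer chain at this position, would move the number beyond the scatter. Also open, going by these compounds, is whether this change reads the same with the diethylamino group of compound 1 at the other end of the shared core.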